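The source may hold more compounds than are shown below. What is called first, only, known or untested is meant among the compounds shown, and "the series" means these compounds.

Working notes on the series. Compound 3 `O=C(c1ccc(F)cc1)N1CCN(c2nc(=O)c3cc(C(F)(F)F)cc([N+](=O)[O-])c3s2)CC1` stands second highest of the three numbers in a physicochemical assay for solubility, read by HPLC; a lower number here means a less soluble compound, a higher number a more soluble compound: in this assay compound 3 gives 1.69 ug/mL. The nearest neighbour is compound 2 `O=C(c1cccc(F)c1)N1CCN(c2nc(=O)c3cc(C(F)(F)F)cc([N+](=O)[O-])c3s2)CC1`, which gives 0.2 ug/mL; the step is an 8.5-fold higher number from compound 2 to compound 3 (0.93 log units; beyond the scatter). The furthest is compound 1 `CC(=O)N1CCN(c2nc(=O)c3cc(C(F)(F)F)cc([N+](=O)[O-])c3s2)CC1`, which gives 83.9 ug/mL; the step is a 50-fold lower number from compound 1 to compound 3 (1.70 log units; beyond the scatter), and the parallel step is a 420-fold lower number from compound 1 to compound 2 (2.62 log units; beyond the scatter).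

Compound 4 `CC(C)(C)C1CCC(C(=O)N2CCN(c3nc(=O)c4cc(C(F)(F)F)cc([N+](=O)[O-])c4s3)CC2)CC1` is not yet measured. The change from compound 3 is 4-(tert-butyl)cyclohexyl in place of 4-fluorophenyl on a carbonyl carbon. For the measured compounds named here, no measured step swaps an aromatic ring for a non-aromatic one on this carbonyl carbon; the only steps that bear on it are those from the methyl of compound 1 to the two fluorophenyl groups, both of which lowered the number by a large amount, and the one between the two fluorophenyl groups, which was modest. Taking those as the guide, a further lowering is expected, with the direction more secure than the size. For compound 4 the expected step is a 4.2-fold lower number from compound 3 to compound 4 (0.63 log units; beyond the scatter), so the estimate for compound 4 in this assay is 0.4 ug/mL, with a range from 0.05 ug/mL to 2.5 ug/mL.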

Compound 4, solubility: < 0.1 ug/mL
Compound 4 ended at the assay's limit; the forecaster's own chance of this, stated with the estimate: 20%; middle value at least 4.0-fold (0.60 log units) away from the limit.
By their numbers in this assay, from the lowest: compound 2; then compound 3; then compound 1. At a limit, below all of these: compound 4.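

The earlier compounds shown here carried only methyl or a fluorophenyl on this carbonyl carbon; with 4-(tert-butyl)cyclohexyl there, compound 4 reads in this assay at a limit of the assay and not at a number: the limit of < 0.1 ug/mL in this assay, at which 1 of the 4 values shown sits. The floors are nevertheless informative, with an at least 16-fold lower number from compound 3 to compound 4 (1.22 log units; beyond the scatter) and an at least 830-fold lower number from compound 1 to compound 4 (2.92 log units; beyond the scatter), so a non-aromatic ring at this position does not recover the number lost on leaving methyl, and it gives a reading clearly under that of the 4-fluorophenyl group. The third floor is an at least 2.0-fold lower number from compound 2 to compound 4 (0.30 log units; that floor lies within the scatter), and as it lies within the scatter, 4-(tert-butyl)cyclohexyl and 3-fluorophenyl cannot be ranked against each other in this assay.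

Still open, going by these compounds, is how much of the step belongs to the cyclohexyl ring and how much to its tert-butyl, a question that a plain cyclohexyl on this carbonyl carbon would address. Also open, on these data alone, is whether a larger group carrying an amine or a carboxylic acid at this position would bring the number back towards that of compound 1 at 83.9 ug/mL.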